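Dimethylamino in place of hydroxy on the shared core

The source may report more compounds than this note shows. Statements on the series, on what has been measured and on what is new or still open speak of the compounds shown alone.

Measured in a functional assay on CCRF-CEM cells (Homo sapiens) for inhibition; on this read-out higher numbers stand for weaker inhibition of growth and lower numbers for stronger inhibition of growth:
- compound 1 `NS(=O)(=O)c1ccc(/C=C/c2ccc(F)cc2)cc1`: 62000 nM
- compound 2 `NS(=O)(=O)c1ccc(/C=C/c2ccc(O)cc2)cc1`: 4500 nM

Going by the values given here, compound 2 holds the lower of the two numbers so far. Compound 3 `CN(C)c1ccc(/C=C/c2ccc(S(N)(=O)=O)cc2)cc1` carries dimethylamino in place of hydroxy on an aromatic carbon. Among the compounds with values here, only one measured step bears on this place: a 14-fold lower number from compound 1 to compound 2 (1.14 log units; beyond the scatter), which is large and shows that a swap here can move this assay well beyond the scatter. That single step says nothing about dimethylamino, so direction remains uncertain. A moderate move to a higher number is expected: a 1.8-fold higher number from compound 2 to compound 3 (0.25 log units; within the scatter). For compound 3 the estimate is 8000 nM, with an expected range of 1500 nM to 40000 nM.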

Compound 3, concentration for 50% growth inhibition: 46000 nM
Compound 3: middle estimate off by 5.8-fold (0.76 log units), on the low side, and the stated range ends below it.
By their numbers in this assay, from the lowest: compound 2; then compounds 3 and 1 (each within the scatter of the next).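

Dimethylamino gives up the gain seen with hydroxy in this assay and shows a 10-fold higher number from compound 2 to compound 3 (1.01 log units; beyond the scatter) as a large step. Against fluoro, dimethylamino shows a 1.3-fold lower number from compound 1 to compound 3 (0.13 log units; within the scatter) and stays within the scatter. Among these three groups at this position, therefore, only hydroxy stands apart, and nothing available explains this separation.

On these data alone, whether an amino group or a methoxy group would fall with hydroxy or with the other two remains open. So does the question of whether this separation holds on other cell lines.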